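A Benzoyl Group in Place of Nitro on a Weak Series

The compounds below may be only part of what the source reports. "The series", "measured", "known", "first", "only" and "open" are said of these compounds alone.

Compound 1 `COc1cc(Cn2cc(COc3cccc(/C=C4/C(=O)Nc5ccccc54)c3)nn2)cc(OC)c1`: in a functional assay on PC-3 cells (Homo sapiens) for inhibition, read by MTT assay, with a stated time of 48 h (on this read-out lower numbers stand for stronger inhibition and higher numbers for weaker inhibition), compound 1 gives 37100 nM.
Compound 2 `O=C1Nc2ccc(Cl)cc2/C1=C/c1cccc(OCc2cn(Cc3ccccc3)nn2)c1`: in this assay compound 2 gives only a limit, > 50000 nM.
Compound 3 `O=C1Nc2ccc([N+](=O)[O-])cc2/C1=C\c1cccc(OCc2cn(Cc3ccccc3)nn2)c1`: in this assay compound 3 also gives only a limit, > 50000 nM.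

Compound 3 thus sits at the limit of > 50000 nM in this assay, at which 2 of the 3 values shown sit, so it has no number of its own and cannot be ranked against compound 2; only compound 1 offers an actual number, and that number is itself far from potent. Among the compounds with values here, no two measured compounds differ in a single place, so no step has been measured here.

Compound 4 `O=C1Nc2ccc(C(=O)c3ccccc3)cc2/C1=C\c1cccc(OCc2cn(Cc3ccccc3)nn2)c1` differs from compound 3 by benzoyl in place of nitro on an aromatic carbon. With nothing to lean on but the weak values shown, no step beyond the scatter in this assay is expected, in either direction. Compound 4 is therefore estimated at 50000 nM, with a range from 15000 nM to 160000 nM, because compound 3 stands at > 50000 nM and the estimated step from compound 3 to compound 4 is a number no higher from compound 3 to compound 4 (the limit leaves the size open).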

Compound 4, half-maximal inhibitory concentration: > 50000 nM
Compound 4 ended at the assay's limit (the forecaster's own chance of this, stated with the estimate: 60%); the middle value lies on the limit itself.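

Within the data shown here, compound 3 and compound 4 each give only a limit of the assay rather than a number, so no step between them can be read: the limit of > 50000 nM in this assay, at which 3 of the 4 values shown sit. The compounds shown leave open whether benzoyl in place of nitro on an aromatic carbon changes inhibition at all, in either direction.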